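This account rests on a few compounds, and the source may have more. Where it says the series, first, only, none or still open, it means among the compounds named here.

Measured so far in a functional assay on the whole organism (strain Swiss albino) for inhibition, with Mus musculus as the target, in the writhing test, with stated times of 60 min and 15 min, at a dose of 100 mg/kg by the oral route; on this read-out lower numbers stand for less inhibition and higher numbers for more inhibition at the one dose given (going by the name of the read-out):
compound 1 `COc1cc2c(cc1OC)C(CC(=O)O)CC2` gives 44%
compound 2 `COc1cc2c(cc1OC)C(CC(=O)N(C)C)CC2` gives 22.6%
compound 3 `CCN(CC)C(=O)CC1CCc2cc(OC)c(OC)cc21` gives 27.4%

Compound 3 stands second highest of the three numbers. Its nearest neighbour is compound 2, and the step of a number 4.8 percentage points higher from compound 2 to compound 3 (within the scatter) lies within the scatter, so the two amides cannot be ordered against each other. Compound 1 is furthest off: the step of a number 16.6 percentage points lower from compound 1 to compound 3 (beyond the scatter) lies beyond the scatter, as does a number 21.4 percentage points lower from compound 1 to compound 2 (beyond the scatter). Both steps from the acid to an amide run the same way and are modest in size.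

Compound 4 `CCCCNC(=O)CC1CCc2cc(OC)c(OC)cc21` has yet to be measured in this assay. It differs from compound 3 as follows: butylamino in place of diethylamino on a carbonyl carbon.

Two kinds of step bear on this change. Going by the values given here, the only step between two amides, a number 4.8 percentage points higher from compound 2 to compound 3 (within the scatter), is within the scatter, which argues for little movement when one amide nitrogen substituent is traded for another. The steps of a number 21.4 percentage points lower from compound 1 to compound 2 (beyond the scatter) and a number 16.6 percentage points lower from compound 1 to compound 3 (beyond the scatter) concern the hydroxy and not the amide substituent. Among the compounds with values here, no measured step covers an amide with 1 hydrogen-bond donor, so the effect of that feature is unknown. On this basis the expected step of a number 2.6 percentage points higher from compound 3 to compound 4 (within the scatter) is none beyond the scatter. Compound 4 is estimated at 30%, with a range of 17% to 43%.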

Compound 4, a percentage reported as inhibition, in the whole organism at one dose (the size of the read-out at that dose, not a potency): 39.4%
Compound 4: the middle estimate sits 9.4 percentage points below what was measured; low and high end bracket the measured number.
By their numbers in this assay, from the lowest: compounds 2 and 3 (each within the scatter of the next); then compounds 4 and 1 (each within the scatter of the next).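

In this assay, going by these compounds alone, the substituent on the amide nitrogen turns out to matter at this carbonyl carbon: with the heavy atom count unchanged, the step of a number 12 percentage points higher from compound 3 to compound 4 (beyond the scatter) and the step of a number 16.8 percentage points higher from compound 2 to compound 4 (beyond the scatter) are the first amide-to-amide steps to clear the scatter. The loss seen earlier on replacing hydroxy therefore does not hold for every amide, since the step of a number 4.6 percentage points lower from compound 1 to compound 4 (within the scatter) leaves the butylamino amide and the acid unseparated, and the pattern of loss is confined to compound 2 and compound 3, with compound 4 going against it. No measured evidence on hand explains the rise with butylamino.

Butylamino differs from diethylamino both in carrying the amide hydrogen and in having a single chain, so the compounds shown cannot assign the step to either feature; a butyl(methyl)amino amide, which keeps the chain and lacks that hydrogen, would separate the two. Whether chain length tracks the read-out also remains open, as ethylamino and hexylamino amides are not among the compounds shown.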